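Chalcones on a fluorobiphenyl core: a methoxy ring repositioned

The compounds below may be only part of what the source reports. "The series", "measured", "known", "first", "only" and "open" are said of these compounds alone.

Measured compounds:
compound 1 `COc1ccc(/C=C/C(=O)c2cccc(-c3cccc(F)c3)c2)cc1` gives 740 nM
compound 2 `O=C(/C=C/c1cccc(Br)c1)c1cccc(-c2cccc(F)c2)c1` gives 6550 nM
compound 3 `O=C(/C=C/c1ccc(Cl)cc1)c1cccc(-c2cccc(F)c2)c1` gives 9060 nM

In a functional assay on CNE-2 cells (Homo sapiens) for cytotoxicity, read by sulforhodamine B assay, with a stated time of 48 h (on this read-out lower numbers stand for stronger inhibition and higher numbers for weaker inhibition), compound 3 has the highest of the three numbers; compound 2 sits within the scatter of it, while compound 1 stands well apart with its far lower number. The shared core carries a fluorophenyl-substituted aryl ketone, and the compounds differ only in the aryl group on the double-bonded chain carbon.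

The step from compound 3 to compound 4 `COc1ccccc1/C=C/C(=O)c1cccc(-c2cccc(F)c2)c1` is 2-methoxyphenyl in place of 4-chlorophenyl on a double-bonded chain carbon bound to a double-bonded chain carbon. Going by the values given here, two measured steps bear on it: a 12-fold higher number from compound 1 to compound 3 (1.09 log units; beyond the scatter) and an 8.9-fold higher number from compound 1 to compound 2 (0.95 log units; beyond the scatter). Both show that a methoxyphenyl ring gave a far lower number than a halogenated ring. Among the compounds with values here, compound 4 returns to a methoxy-bearing ring, though at a different ring position, for which no measured pair exists. A lower number is therefore expected, with wide uncertainty about how much of the gap to compound 1 is recovered; the expected step is a 4.5-fold lower number from compound 3 to compound 4 (0.66 log units; beyond the scatter). Compound 4 is estimated at 2000 nM, between 500 nM and 8000 nM.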

Compound 4, half-maximal inhibitory concentration: 10400 nM
For compound 4 the middle estimate is 5.2-fold (0.72 log units) below the measured one; measured number above the stated range.
By their numbers in this assay, from the lowest: compound 1; then compounds 2, 3 and 4 (each within the scatter of the next).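

In this assay a methoxy group alone does not set this position apart: 2-methoxyphenyl stays level with the halogenated rings, as shown by a 1.1-fold higher number from compound 3 to compound 4 (0.06 log units; within the scatter) and by a 1.6-fold higher number from compound 2 to compound 4 (0.20 log units; within the scatter) within the scatter. The real gap lies between the two methoxyphenyl groups, with a 14-fold higher number from compound 1 to compound 4 (1.15 log units; beyond the scatter) on the same double-bonded chain carbon, so among these compounds the place of the methoxy on the ring matters, not merely its presence. No evidence here explains this difference.

The compounds shown leave open whether another group on the ring, such as an amine or a second methoxy, would match the low number of compound 1.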